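The source may hold more compounds than are shown below. What is called first, only, known or untested is meant among the compounds shown, and "the series" means these compounds.

Three compounds that share one core were tested in a functional assay on DU-145 cells (Homo sapiens) for inhibition, read by sulforhodamine B assay, with a stated time of 72 h; a higher number here means a weaker inhibitor of growth, a lower number a stronger inhibitor of growth: compound 1 `C=C1CC[C@@H]2[C@](C)(COC(=O)c3cccnc3)[C@H](OC(=O)c3cccnc3)CC[C@@]2(C)[C@@H]1/C=C/C1=CCOC1=O`, compound 2 `C=C1CC[C@@H]2[C@](C)(COC(=O)CCN(C)C)[C@H](OC(=O)CCN(C)C)CC[C@@]2(C)[C@@H]1/C=C/C1=CCOC1=O` and compound 3 `C=C1CC[C@@H]2[C@](C)(COC(=O)CCCCC3CCSS3)[C@H](OC(=O)CCCCC3CCSS3)CC[C@@]2(C)[C@@H]1/C=C/C1=CCOC1=O`. Compound 1 gives > 30000 nM, which is a limit of the assay and not a number. Compound 2 gives 25300 nM. Compound 3 gives 11800 nM, the lower of the two actual numbers, and its gap to compound 2 lies beyond the usual scatter.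

Compound 4 `C=C1CC[C@@H]2[C@](C)(COC(=O)CCCCC3CCSS3)[C@H](O)CC[C@@]2(C)[C@@H]1/C=C/C1=CCOC1=O` has not yet been measured in this assay. It differs from compound 3 in one place: a hydrogen atom in place of a group of 11 heavy atoms (8 carbon, 1 oxygen, 2 sulfur; one five-membered non-aromatic ring with 2 hetero atoms), on an oxygen on a saturated carbon. The group with the five-membered non-aromatic ring leaves an oxygen on a saturated carbon, and a hydrogen atom takes its place. Among the compounds with values here, no measured pair of compounds shows what such a change does in this assay, so the expectation is a cautious one. The estimated change is a 1.1-fold lower number from compound 3 to compound 4 (0.03 log units; within the scatter), and it is expected to stay within the scatter, with no clear direction. For compound 4 the expected value is 11000 nM, with an estimated range from 4500 nM to 27000 nM.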

Compound 4, concentration for 50% growth inhibition: > 30000 nM
Compound 4: only a limit was reported; the forecaster's own chance of this, stated with the estimate: 12%; middle value at least 2.7-fold (0.43 log units) from the limit.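

In this assay, the oxygen on a saturated carbon is not a neutral place for this change: a hydrogen atom in place of the group with the five-membered non-aromatic ring gives an at least 2.5-fold higher number from compound 3 to compound 4 (0.40 log units; beyond the scatter). Within the data shown here, compounds 1, 2 and 3 differ from one another in more than one place, so they could not show what a single group contributes here, and this step is the first to do so. The value of compound 4 is a limit and not a number, so the step gives only a lower bound on the size of the change: the limit of > 30000 nM in this assay, at which 2 of the 4 values shown sit.

The compounds shown leave open whether a simple acetyl ester or a longer carbon chain at this oxygen would keep the growth inhibition of compound 3. They also leave open what the other copy of the group in compound 3 contributes.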